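A few compounds are considered here, and "the series" means these few. Any claim that something is new, unique, unknown or untested is made for them only; others in the source may bear on it.

Compound 1 `O=S1(=O)C=Cc2cccc(Nc3ccc(C(F)(F)F)cc3)c21`: 2440 nM
Compound 2 `O=S1(=O)C=Cc2cccc(Nc3cccc(F)c3)c21`: 2550 nM
Compound 3 `COc1ccc(Nc2cccc3c2S(=O)(=O)C=C3)cc1`: not yet measured

In a functional assay on A549 cells (Homo sapiens) for antiproliferative activity, read by MTT assay, with a stated time of 72 h (a lower number here means a stronger inhibitor, a higher number a weaker inhibitor), compound 1 gives 2440 nM and compound 2 gives 2550 nM. These two values lie within the scatter of each other, so compound 1 stands level with compound 2 and the numbers set no order.

Compound 3 carries methoxy in place of trifluoromethyl on an aromatic carbon, para to a large group (methoxy in place of trifluoromethyl on an aromatic carbon). Going by the values given here, no measured pair sizes this change, so the expectation is weakly grounded. No step beyond the scatter is expected in this assay, and no direction is favoured.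

The expected change is a 1.0-fold higher number from compound 1 to compound 3 (0.01 log units; within the scatter).

Compound 3 is estimated at 2500 nM, with an expected range of 900 nM to 7000 nM.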

Compound 3, half-maximal inhibitory concentration: 2590 nM
Compound 3: the middle estimate sits 1.0-fold (0.02 log units) below what was measured, within the range that was stated.
By their numbers in this assay, from the lowest: compounds 1, 2 and 3 (each within the scatter of the next).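

Going by these compounds alone, the step sizes this change for the first time: in this assay, methoxy in place of trifluoromethyl on an aromatic carbon, para to a large group, gives a 1.1-fold higher number from compound 1 to compound 3 (0.03 log units; within the scatter) and so lies within the scatter. At this position the assay therefore does not separate the two groups, although methoxy has fewer heavy atoms and brings a hydrogen-bond acceptor that trifluoromethyl lacks. No measurement shown here offers an explanation for this result.

From the compounds shown here alone, whether any group at this position can move the number beyond the scatter stays open, for example an amine or a carboxylic acid. Going by these compounds, a longer chain such as butoxy is also open, since a single step at one position cannot show how far this insensitivity extends.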